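The source may hold more compounds than are shown below. What is called first, only, known or untested is meant among the compounds shown, and "the series" means these compounds.

Working notes on the series. In a functional assay on HT-29 cells (Homo sapiens) for antiproliferative activity, read by MTT assay, with a stated time of 48 h (a higher number here means a weaker inhibitor, a lower number a stronger inhibitor), compound 1 (`COc1cc(/C=N/c2c(C#N)ncn2-c2ccc(F)cc2)ccc1O`) gives 20100 nM and compound 2 (`N#Cc1ncn(-c2ccc(F)cc2)c1/N=C/c1ccc(O)cc1`) gives 20400 nM while compound 3 (`COc1cc(/C=N/c2c(C#N)ncn2Cc2ccc(F)cc2)ccc1O`) gives 21500 nM and so stands level with the other two, all three within the scatter of one another.

Compound 4 (`COc1ccc(/C=N/c2c(C#N)ncn2Cc2ccc(F)cc2)cc1OC`) has methyl in place of hydrogen on an oxygen on an aromatic ring, which reads as hydroxy to methoxy. Going by the values given here, two measured steps bear on it only indirectly. Hydrogen in place of methoxy on an aromatic carbon gave a 1.0-fold higher number from compound 1 to compound 2 (0.01 log units; within the scatter) and 4-fluorobenzyl in place of 4-fluorophenyl on an aromatic nitrogen gave a 1.1-fold higher number from compound 1 to compound 3 (0.03 log units; within the scatter) and neither step goes beyond the scatter. Among the compounds with values here, all three measured compounds keep the hydroxy, so no measured step tests its capping, and the range is kept wide. The step expected in this assay is a 1.0-fold higher number from compound 3 to compound 4 (0.01 log units; within the scatter) and thus none beyond the scatter, with no direction favoured. For compound 4 the estimate is 22000 nM with an expected range of 9000 nM to 55000 nM in this series.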

Compound 4, half-maximal inhibitory concentration: 13800 nM
Beside the measured number, compound 4's estimate is 1.6-fold (0.20 log units) above it; the range from low to high includes it.
By their numbers in this assay, from the lowest: compounds 4, 1, 2 and 3 (each within the scatter of the next).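

In this assay, going by these compounds alone, the hydroxy is put to a direct test for the first time: methyl in place of hydrogen on an oxygen on an aromatic ring gives a 1.6-fold lower number from compound 3 to compound 4 (0.19 log units; within the scatter), so this pair shows no clear dependence on the free hydroxy. With compound 3 and compound 4 reading level, hydroxy and methoxy at this place cannot be told apart in this assay, and the four compounds shown remain within the scatter of their neighbours in the order of their numbers. No measurement on hand offers a reason for this result.

On these data alone, whether the same holds with 4-fluorophenyl on the aromatic nitrogen remains open. Also open, as far as these compounds go, is how this place would read with an amine in place of the hydroxy, or with a carboxylic acid or a longer chain on the oxygen.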